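S-Methylation of a thiol on a fused bicyclic core

A few compounds are considered here, and "the series" means these few. Any claim that something is new, unique, unknown or untested is made for them only; others in the source may bear on it.

Compound 1, `O=C(CSc1nncc2cncn12)c1ccccc1`: > 48000 nM
Compound 2, `CC(C)c1ncn2c(S)nncc12`: > 48000 nM
Compound 3, `CCCc1nc(C)c2c(C)nn(CC)c(=O)n12`: > 48000 nM

All three measured compounds were tested in a functional assay for inhibition, with Homo sapiens as the target; on this read-out higher numbers stand for weaker inhibition and lower numbers for stronger inhibition. Compound 1 gives only the assay limit, > 48000 nM. Compound 2 likewise gives only the assay limit, > 48000 nM. Compound 3 also returns the assay limit, > 48000 nM. For the measured compounds named here, no value is a number; every result sits at the limit of > 48000 nM in this assay, at which 3 of the 3 values shown sit, so compound 2 cannot be placed relative to the others, and no step between measured compounds can be drawn.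

Compound 4, `CSc1nncc2c(C(C)C)ncn12`, is not yet measured in this assay. It differs from compound 2 by methyl in place of hydrogen on a sulfur, a methyl in place of hydrogen on a sulfur. With nothing in the series rising off the limit, no direction of change can be read from the measured compounds. The expectation for compound 4 in this assay is that it again reports a limit rather than a number, and the estimate is 60000 nM, within 20000 nM to 200000 nM. The step this estimate implies is a step that the limit leaves unreadable from compound 2 to compound 4, which is expected to be no change beyond the usual scatter.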

Compound 4, half-maximal inhibitory concentration: > 48000 nM
Compound 4 was reported as a limit; the forecaster's own chance of this, stated with the estimate: 80%; the middle value is on the limit's open side.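

In this assay compound 4 gives > 48000 nM, which is a limit and not a number. No step can be read between compound 2 and compound 4, as both report only limits: the limit of > 48000 nM in this assay, at which 4 of the 4 values shown sit.

The compounds shown leave open whether methyl in place of hydrogen on a sulfur changes inhibition at all.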